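Swapping Chloro for Fluoro on a Bis-Heteroaryl Amidine

The source may hold more compounds than are shown below. What is called first, only, known or untested is meant among the compounds shown, and "the series" means these compounds.

Three compounds sharing an amidine-bearing core were tested in a functional assay on 786-0 cells (Homo sapiens) for inhibition, read by sulforhodamine B assay, with a stated time of 48 h; a higher number here means a weaker inhibitor of growth, a lower number a stronger inhibitor of growth. Compound 1 `N=C(N)c1ccc(-c2ccc(-c3cc(Cl)cc(Cl)c3)s2)s1`, with two chlorines on its outer ring, gives 1980 nM. Compound 2 `N=C(N)c1ccc(-c2ccc(-c3ccc(Cl)cc3)o2)o1`, carrying a single chloro on an aromatic carbon of a six-membered aromatic ring of carbon only, gives 1850 nM. Compound 3 `COc1cc(OC)cc(-c2ccc(-c3ccc(C(=N)N)o3)o2)c1`, with two methoxy groups instead, gives 4150 nM.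

Among these, compound 2 has the lowest number, but compound 1 sits within the usual scatter of it, so the two cannot be told apart; only compound 3 lies beyond the scatter, with a clearly higher number.

Compound 4 `N=C(N)c1ccc(-c2ccc(-c3ccc(F)cc3)o2)o1` differs from compound 2 in one place: fluoro in place of chloro on an aromatic carbon. For the measured compounds named here, no measured pair here isolates such a halogen swap, so there is no step to lean on. Because compound 2 gives 1850 nM and the change is small in count, the step is expected to stay within the scatter, if anything drifting toward a slightly higher number.

The estimate for compound 4 in this assay is therefore 2600 nM, within a range of 1200 nM to 5600 nM. This estimate corresponds to a step of a 1.4-fold higher number from compound 2 to compound 4 (0.15 log units; within the scatter).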

Compound 4, concentration for 50% growth inhibition: 1660 nM
Compound 4: the middle estimate sits 1.6-fold (0.19 log units) above what was measured; the range from low to high includes it.
By their numbers in this assay, from the lowest: compounds 4, 2 and 1 (each within the scatter of the next); then compound 3.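

In this assay, fluoro in place of chloro on an aromatic carbon of a six-membered aromatic ring of carbon only, para to a large group, gives a 1.1-fold lower number from compound 2 to compound 4 (0.05 log units; within the scatter) so the two compounds cannot be told apart by this read-out. For the compounds shown here, the earlier compounds differed from one another in more than one place, so none of them could speak for this position alone; this pair is the first to isolate a single change there. At this position, then, the two halogens give numbers within the usual scatter of each other, although nothing measured here explains that result.

Going by these compounds, this one pair covers only chloro and fluoro, so it remains open whether a quite different group at the same position, such as an amine, a carboxylic acid or a longer alkyl chain, would also leave the number within the scatter or move it clearly. On these data alone, it also remains open whether the same halogen swap would give a similar step on the core of compound 1, which carries two chlorines on its outer ring.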